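Cytotoxicity notes on compounds 1 to 4

The source may hold more compounds than are shown below. What is called first, only, known or untested is meant among the compounds shown, and "the series" means these compounds.

Compound 1 `CS(=O)(=O)N1CCC2(CC1)OOC1(CCCCCC1)OO2` was run in a functional assay on Huh-7 cells (Homo sapiens) for cytotoxicity, read by MTT assay, with a stated time of 72 h; on this read-out higher numbers stand for lower toxicity in this test and lower numbers for higher toxicity in this test. In this assay compound 1 gives only a limit, > 100 ug/mL. Compound 2 `CCS(=O)(=O)N1CCC2(CC1)OOC1(CCCCCC1)OO2` differs from compound 1 by methyl in place of hydrogen on a saturated chain carbon bound to a sulfonyl sulfur. In this assay compound 2 likewise gives only a limit, > 100 ug/mL. The step from compound 1 to compound 2 is a step that the two limits leave unreadable from compound 1 to compound 2, since both values sit at the limit of > 100 ug/mL in this assay, at which 3 of the 3 values shown sit. Compound 3 `CCCS(=O)(=O)N1CCC2(CC1)OOC(C)(CC)OO2` has another core; the difference between the core of compound 1 and the core of compound 3 is not broken down here. In this assay compound 3 gives only a limit, > 100 ug/mL.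

Compound 4 `CCCC1(C)OOC2(CCN(S(=O)(=O)CCC)CC2)OO1` is not yet measured. It differs from compound 3 by methyl in place of hydrogen on a saturated chain carbon, two bonds along the chain from a saturated ring carbon. This is the same kind of change as that from compound 1 to compound 2, but not the same: there the place is on a saturated chain carbon bound to a sulfonyl sulfur, here it is on a saturated chain carbon, two bonds along the chain from a saturated ring carbon. The earlier step, a step that the two limits leave unreadable from compound 1 to compound 2, gave no readable size because of the limit of > 100 ug/mL in this assay, at which 3 of the 3 values shown sit. The step from compound 3 to compound 4 is estimated as a step that the limit leaves unreadable from compound 3 to compound 4, beside that earlier one. This rests on compound 3, which in this assay gives only a limit, > 100 ug/mL. Compound 4 is expected to give 150 ug/mL in this assay. Its range is estimated from 60 ug/mL to 400 ug/mL, and most likely the assay again reports only a limit.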

Compound 4, half-maximal cytotoxic concentration: > 100 ug/mL
Compound 4 gave a limit, no number; the forecaster's own chance of this, stated with the estimate: 85%; the middle value does not contradict the limit.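

In this assay no new step can be read between compound 3 and compound 4, and the pair of compound 1 and compound 2 stays equally unreadable, because all four values are limits and not numbers: the limit of > 100 ug/mL in this assay, at which 4 of the 4 values shown sit.
The compounds shown leave open how the four compare with one another in this assay, and whether any of the changes among them alters cytotoxicity at all.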